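The compounds below may be only part of what the source reports. "The series", "measured", "known", "first", "only" and "open" are said of these compounds alone.

In a functional assay on MCF7 cells (Homo sapiens) for cytotoxicity, read by sulforhodamine B assay, with a stated time of 48 h (on this read-out lower numbers stand for stronger inhibition of growth and higher numbers for weaker inhibition of growth), compound 1 (`Cc1nn(-c2ccccc2)c(Oc2ccc(-c3nc4cc([N+](=O)[O-])ccc4[nH]3)cc2)c1/C=N/NC(N)=O`) gives 13800 nM and compound 2 (`Cc1nn(-c2ccccc2)c(Oc2ccc(-c3nc4cc([N+](=O)[O-])ccc4[nH]3)cc2)c1/C=N/NC(N)=S`) gives 9200 nM while compound 3 (`COc1ccc(N/N=C/c2c(C)nn(-c3ccccc3)c2Oc2ccc(-c3nc4cc(C(N)=O)ccc4[nH]3)cc2)cc1`) gives 13600 nM, so compound 3 stands level with the other two, all three lying within the scatter of one another.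

Compound 4 (`Cc1nn(-c2ccccc2)c(Oc2ccc(-c3nc4cc(C(N)=O)ccc4[nH]3)cc2)c1/C=N/NC(N)=S`) comes from compound 3 through a single change: a group of 3 heavy atoms (1 carbon, 1 nitrogen, 1 sulfur; no ring) in place of a group of 8 heavy atoms (7 carbon, 1 oxygen; one six-membered aromatic ring of carbon only), on an amine nitrogen.

Within the data shown here, no measured step removes a 4-methoxyphenyl group, so nothing shows this change directly. The closest evidence is compound 2, which carries the same entering group on that amine nitrogen and gives 9200 nM, although it differs from compound 4 elsewhere on the shared core. Among the measured compounds shown here, the only measured step, a 1.5-fold lower number from compound 1 to compound 2 (0.18 log units; within the scatter), swaps oxygen for sulfur in that group and stays within the scatter.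

No step beyond the scatter is therefore expected in this assay. The estimated step is a 1.2-fold lower number from compound 3 to compound 4 (0.09 log units; within the scatter). Compound 4 is expected to give 11000 nM, with an estimated range from 5000 nM to 25000 nM.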

Compound 4, concentration for 50% growth inhibition: 9600 nM
The estimate for compound 4 lay 1.1-fold (0.06 log units) above the measured number; the range from low to high includes it.
By their numbers in this assay, from the lowest: compounds 2, 4, 3 and 1 (each within the scatter of the next).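

In this assay, putting the small, ring-free group on the amine nitrogen in place of 4-methoxyphenyl gives a 1.4-fold lower number from compound 3 to compound 4 (0.15 log units; within the scatter). At this position, then, losing the aromatic ring and most of the group's heavy atoms does not measurably alter growth inhibition. The same compound adds a second comparison at another site, where carbamoyl in place of nitro on an aromatic carbon gives a 1.0-fold higher number from compound 2 to compound 4 (0.02 log units; within the scatter), so neither change separates the compounds compared.

Going by these compounds, it remains open whether a carboxylic acid or an amine on that aromatic carbon, or a longer alkyl chain on the amine nitrogen, would produce a step beyond the scatter. No measurement available here accounts for these results.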